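Moving one methoxy group on the amide aryl ring

This account rests on a few compounds, and the source may have more. Where it says the series, first, only, none or still open, it means among the compounds named here.

Of the compounds shown here, three sharing one core have been measured in an in vitro assay on BTI-TN-5B1-4 cells for inhibition of Amine oxidase [flavin-containing] A (Homo sapiens), read by fluorescence; on this read-out higher numbers stand for weaker inhibition and lower numbers for stronger inhibition. Compound 1 `COc1cc(NC(=O)c2cc3ccc(OCc4ccccc4)cc3oc2=O)cc(OC)c1` gives 52900 nM. Compound 2 `Cc1cccc(Cl)c1NC(=O)c1cc2ccc(OCc3ccc(F)cc3)cc2oc1=O` gives 59600 nM. Compound 3 `COc1ccc(NC(=O)c2cc3ccc(OCc4ccc(F)cc4)cc3oc2=O)cc1OC` gives 49200 nM, a number that sits within the usual scatter of both compound 1 and compound 2, so the three cannot be told apart on these numbers. Going by the values given here, the one single-point step among them, a 1.2-fold lower number from compound 2 to compound 3 (0.08 log units; within the scatter), is itself within the scatter.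

Compound 4 `COc1cc(NC(=O)c2cc3ccc(OCc4ccc(F)cc4)cc3oc2=O)cc(OC)c1` has not yet been measured. It differs from compound 3 in one place: 3,5-dimethoxyphenyl in place of 3,4-dimethoxyphenyl on an amide-type nitrogen. The measured step that bears most directly on the amide nitrogen is the swap from compound 2 to compound 3, and it moved the number by almost nothing. Among the compounds with values here, compound 1 also carries the 3,5-dimethoxyphenyl group that enters here, and its value stands close to that of compound 3, though compound 1 and compound 3 differ in a second place as well and no single step links them. The expectation for this assay is therefore a step of a 1.0-fold higher number from compound 3 to compound 4 (0.02 log units; within the scatter), that is, no change beyond the scatter. Compound 4 is estimated at 51000 nM, with a range from 25000 nM to 105000 nM.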

Compound 4, half-maximal inhibitory concentration: 52600 nM
Beside the measured number, compound 4's estimate is 1.0-fold (0.01 log units) below it; measured number inside the range.
By their numbers in this assay, from the lowest: compounds 3, 4, 1 and 2 (each within the scatter of the next).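

In this assay, moving one methoxy group, so that 3,5-dimethoxyphenyl stands in place of 3,4-dimethoxyphenyl on the amide-type nitrogen, keeps the same atoms and gives no change beyond the scatter (a 1.1-fold higher number from compound 3 to compound 4 (0.03 log units; within the scatter)). The same position also tolerates a more different group within the scatter, with 3,5-dimethoxyphenyl in place of 2-chloro-6-methylphenyl (a 1.1-fold lower number from compound 2 to compound 4 (0.05 log units; within the scatter)), and the new compound supplies the first single-place link to compound 1, where fluoro in place of hydrogen on an aromatic carbon also stays within the scatter (a 1.0-fold lower number from compound 1 to compound 4 (0.00 log units; within the scatter)). Every change read so far at these two places therefore leaves the number within the scatter, and nothing available here offers an explanation for this.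

All the amide aryl groups shown are dimethoxyphenyl or 2-chloro-6-methylphenyl, so these compounds cannot say whether this position would respond to an amine or a carboxylic acid on that ring, or to a longer chain in place of methoxy. On these data alone, it also stays open whether chloro in place of fluoro would shift the number, since fluoro and hydrogen are the only two options compared at that place.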